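The source may report more compounds than this note shows. Statements on the series, on what has been measured and on what is new or still open speak of the compounds shown alone.

The shared core of compound 1 `COc1cc(-c2nnc3n2NC(c2cccs2)C(C(=O)c2ccccc2)S3)cc(OC)c1OC` carries a phenyl ketone, and in a functional assay on HepG2 cells (Homo sapiens) for cytotoxicity, read by MTT assay, with a stated time of 48 h (a higher number here means a weaker inhibitor, a lower number a stronger inhibitor), compound 1 gives only a limit of the assay, > 100000 nM. Compound 3 `COc1cc(-c2nnc3n2NC(c2cccs2)C(C(=O)c2ccc(Cl)cc2)S3)cc(OC)c1OC` differs by a chloro in place of hydrogen on an aromatic carbon, and in this assay compound 3 gives 13200 nM; the step of an at least 7.5-fold lower number from compound 1 to compound 3 (0.87 log units; beyond the scatter) is beyond the scatter. Compound 2 `COc1ccc(C(=O)C2Sc3nnc(-c4cc(OC)c(OC)c(OC)c4)n3NC2c2ccco2)cc1` bears a furan and a 4-methoxyphenyl ketone. In this assay compound 2 gives only a limit, > 100000 nM. So compound 2 stands where most of the measured values stand: at the limit of > 100000 nM in this assay, at which 2 of the 3 values shown sit, with no number of its own.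

Compound 4 `COc1cc(-c2nnc3n2NC(c2ccco2)C(C(=O)c2ccccc2C)S3)cc(OC)c1OC` is not yet measured. The change from compound 2 is 2-methylphenyl in place of 4-methoxyphenyl on a carbonyl carbon. Among the compounds with values here, no measured step covers a methylphenyl ketone; the only step on this part of the core, from compound 1 to compound 3, concerns a chloro and says nothing directly about this swap. Since compound 2 sits at a limit, the number for compound 4 is expected to sit near it, with the step of an at least 2.0-fold lower number from compound 2 to compound 4 (0.30 log units; that floor lies within the scatter) estimated as uncertain in direction. Compound 4 is estimated at 50000 nM, in a range of 10000 nM to 300000 nM.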

Compound 4, half-maximal inhibitory concentration: 63000 nM
The estimate for compound 4 lay 1.3-fold (0.10 log units) below the measured number; the range from low to high includes it.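

Compound 4 gives the furan-bearing compounds their first actual number in this assay, so this position on the carbonyl carbon can hold an aryl group other than the 4-methoxyphenyl of compound 2 and still give a reading inside the assay's range. The swap to 2-methylphenyl gives an at least 1.5-fold lower number from compound 2 to compound 4 (0.20 log units; that floor lies within the scatter), and since that floor lies within the scatter, it does not establish a real change. The value for compound 2 remains a limit and not a number, so the true size of the step stays unknown: the limit of > 100000 nM in this assay, at which 2 of the 4 values shown sit.

From the compounds shown here alone, it remains open whether a chloro on the aromatic ring of compound 4 would matter here as it did in the step from compound 1 to compound 3. Also open, going by these compounds, is how an amine or a carboxylic acid on that ring would read in this assay.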